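The source may hold more compounds than are shown below. What is called first, only, known or untested is meant among the compounds shown, and "the series" means these compounds.

Measured in a functional assay on HCT-116 cells (Homo sapiens), read by MTT assay, with a stated time of 72 h; a higher number here means a weaker inhibitor, a lower number a stronger inhibitor:
- Compound 1 `CSc1ncnc2c1c(-c1ccsc1)cn2[C@@H]1O[C@H](CO)[C@@H](O)[C@H]1O`: > 20000 nM (a limit)
- Compound 2 `CNc1ncnc2c1c(-c1ccoc1)cn2[C@@H]1O[C@H](CO)[C@@H](O)[C@H]1O`: > 20000 nM (a limit)

Compound 2 has no exact figure in this assay, as its result is the limit > 20000 nM. It shares this position with compound 1, and the whole measured set stands at the limit of > 20000 nM in this assay, at which 2 of the 2 values shown sit. Compound 3 `CNc1ncnc2c1c(-c1ccsc1)cn2[C@@H]1O[C@H](CO)[C@@H](O)[C@H]1O` has thiophen-3-yl in place of furan-3-yl on an aromatic carbon of a five-membered aromatic ring with 1 nitrogen, (thiophen-3-yl in place of furan-3-yl on an aromatic carbon). Compound 1 already carries thiophen-3-yl, and its result is the limit > 20000 nM. Among the measured compounds shown here, no measured pair isolates this exchange, so the expectation rests on these two limits. The expected change, a number no higher from compound 2 to compound 3 (the limit leaves the size open), is none beyond the scatter, with no direction favoured. For compound 3 the estimate is 20000 nM, with an expected range from 5000 nM to 40000 nM, and a further limit is the likeliest report.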

Compound 3, half-maximal inhibitory concentration: > 20000 nM
Compound 3: only a limit was reported (the forecaster's own chance of this, stated with the estimate: 75%); the middle value lies on the limit itself.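

The steps from compound 1 and from compound 2 to compound 3 cannot be read, as all three results are limits: the limit of > 20000 nM in this assay, at which 3 of the 3 values shown sit.

The compounds shown leave open whether exchanging furan-3-yl for thiophen-3-yl, or methylsulfanyl for methylamino, changes the result in this assay at all.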